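Swapping an Oxazole for a Fluoromethoxyphenyl: Cytotoxicity Outlook

The compounds below may be only part of what the source reports. "The series", "measured", "known", "first", "only" and "open" are said of these compounds alone.

Compound 1 `N#CCCCn1c(Cn2c(=O)n(-c3ncco3)c3ccncc32)cc2cc(Cl)ccc21` and compound 2 `CC1(n2c(=O)n(Cc3cc4cc(Cl)ccc4n3CCCS(C)(=O)=O)c3cnccc32)CC1` were both tested in an ADME assay on HeLa cells (Homo sapiens) for cytotoxicity, read by ATP content, with a stated time of 3 days; a higher number here means that more compound is tolerated, a lower number that less compound is tolerated. Compound 1 reaches only the limit of the assay, > 50000 nM, rather than a number. Compound 2 likewise stops at the limit, > 50000 nM. So far the picture is the limit of > 50000 nM in this assay, at which 2 of the 2 values shown sit. Compound 3 `COc1ccc(-n2c(=O)n(Cc3cc4cc(Cl)ccc4n3CCCC#N)c3cnccc32)c(F)c1` differs from compound 1 by one change: 2-fluoro-4-methoxyphenyl in place of 1,3-oxazol-2-yl on an aromatic nitrogen. Among the measured compounds shown here, no measured step between two compounds exists here, so no change beyond the scatter is expected, and the step is estimated as a number no higher from compound 1 to compound 3 (the limit leaves the size open). Compound 3 is therefore expected to give about 50000 nM, between 20000 nM and 100000 nM.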

Compound 3, half-maximal cytotoxic concentration: > 50000 nM
Compound 3: only a limit was reported (the forecaster's own chance of this, stated with the estimate: 70%); the middle value lies on the limit itself.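

Compound 1 and compound 3 both stop at a limit in this assay, so no step can be read from swapping 1,3-oxazol-2-yl for 2-fluoro-4-methoxyphenyl. Still open is the concentration at which any of these compounds becomes toxic to the cells, with the picture unchanged: the limit of > 50000 nM in this assay, at which 3 of the 3 values shown sit.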